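The source may report more compounds than this note shows. Statements on the series, on what has been measured and on what is new or still open speak of the compounds shown alone.

Compound 3, with the structure `Cc1ccc(S(=O)(=O)N2CC=C(Br)CC2)cc1`, was tested in a functional assay on WiDr cells (Homo sapiens) for antiproliferative activity, read by sulforhodamine B assay, with a stated time of 48 h; on this read-out higher numbers stand for weaker inhibition of growth and lower numbers for stronger inhibition of growth. In this assay compound 3 gives > 100000 nM, a value that is a limit of the assay rather than a number. Compound 2, with the structure `Cc1ccc(S(=O)(=O)N2CC=C(Cl)CC2)cc1`, also reaches only a limit, giving > 100000 nM. The step from compound 2 to compound 3, a step that the two limits leave unreadable from compound 2 to compound 3, therefore cannot be read, because both values sit at the limit of > 100000 nM in this assay, at which 2 of the 3 values shown sit. Compound 1, with the structure `Cc1ccc(S(=O)(=O)N2CC[C@@H](Br)C[C@@H]2c2ccccc2)cc1`, is the only one of the three measured compounds with a number: it gives 36000 nM. Within the data shown here, no step between compound 1 and compound 3 is on record; their two values show only that compound 1 has a number where compound 3 has a limit.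

Compound 4, with the structure `CCCCCCCC1C=C(Br)CCN1S(=O)(=O)c1ccc(C)cc1`, differs from compound 3 by heptyl in place of hydrogen on a saturated ring carbon. Among the measured compounds shown here, no measured step bears directly on this change. For the measured compounds named here, the only hint is that compound 1, which carries a large group on the same kind of ring carbon, gives a number, 36000 nM. The step from compound 3 to compound 4 is expected to be an at least 2.0-fold lower number from compound 3 to compound 4 (0.30 log units; that floor lies within the scatter), toward stronger inhibition. Compound 4 is estimated at 50000 nM, within a range from 15000 nM to 200000 nM.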

Compound 4, concentration for 50% growth inhibition: 40000 nM
For compound 4 the middle estimate is 1.3-fold (0.10 log units) above the measured one, within the range that was stated.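

Putting heptyl in place of hydrogen on this saturated ring carbon, next to the ring nitrogen, gives in this assay an at least 2.5-fold lower number from compound 3 to compound 4 (0.39 log units; beyond the scatter), the only step among these compounds that can be read. The earlier pair of compounds 2 and 3 showed no readable change, whereas this change at this position turns a limit into a number. The size of the step is only a floor, because compound 3 stands at a limit of the assay and not at a number: the limit of > 100000 nM in this assay, at which 2 of the 4 values shown sit.

The compounds shown leave open how the true distance between the two compounds compares with that floor, and whether chloro in place of bromo would matter once heptyl is present. They also leave open how a shorter chain such as propyl, a longer chain such as decyl, or a chain ending in an amine or a carboxylic acid would compare with heptyl.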